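Losing the 3-methylbut-2-en-1-yl chain from compound 2

The source may report more compounds than this note shows. Statements on the series, on what has been measured and on what is new or still open speak of the compounds shown alone.

Measured in a functional assay on A549 cells (Homo sapiens) for inhibition, read by MTT assay, with a stated time of 72 h; on this read-out higher numbers stand for weaker inhibition and lower numbers for stronger inhibition
Compound 1 `COc1cc(/C=C/C(=O)c2c(OC)cc(O)c(CC=C(C)C)c2O)ccc1O` gives 11800 nM
Compound 2 `COc1ccc(/C=C/C(=O)c2c(OC)cc(O)c(CC=C(C)C)c2O)cc1OC` gives 15700 nM
Compound 3 `COc1cc(/C=C/C(=O)c2c(OC)cc(O)c(CC=C(C)C)c2O)cc(OC)c1OC` gives > 50000 nM as a limit

Compound 2 sits among these values with one close neighbour. That gap is small (a 1.3-fold higher number from compound 1 to compound 2 (0.12 log units; within the scatter)) and comes with a methyl in place of hydrogen on an oxygen. The value of compound 3 is a limit, not a number. Among the measured compounds shown here, in compound 4 `COc1ccc(/C=C/C(=O)c2c(O)cc(O)cc2OC)cc1OC` the change is hydrogen in place of 3-methylbut-2-en-1-yl on an aromatic carbon and no measured step touches this chain. The nearest guide is the added methoxy (an at least 3.1-fold higher number from compound 2 to compound 3 (0.50 log units; beyond the scatter)) since the group leaving here is larger. A rise of similar size in this assay is therefore expected, meaning weaker inhibition. The estimated step is a 2.5-fold higher number from compound 2 to compound 4 (0.41 log units; beyond the scatter) in this direction. Compound 4 is expected at 40000 nM within a range of 15000 nM to 90000 nM by this estimate.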

Compound 4, half-maximal inhibitory concentration: > 50000 nM
Compound 4 ended at the assay's limit; the forecaster's own chance of this, stated with the estimate: 40%; at least 1.2-fold (0.09 log units) between middle value and limit.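

Replacing the 3-methylbut-2-en-1-yl chain with hydrogen gives an at least 3.1-fold higher number from compound 2 to compound 4 (0.50 log units; beyond the scatter) in this assay, meaning weaker inhibition. Among the compounds shown here, compounds 1, 2 and 3 all carry this chain and differ only elsewhere, so this is the first sign that inhibition depends on what sits on this aromatic carbon. The value of compound 4 is a limit, so the full size of the loss stays unknown: the limit of > 50000 nM in this assay, at which 2 of the 4 values shown sit.

On these data alone, what a methyl group, a longer chain or an amine would do on this aromatic carbon remains open. As far as these compounds go, it is also open whether removing the chain from compound 1 would weaken inhibition in the same way.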